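Swapping the benzyl arm for a methoxyphenyl group

The source may hold more compounds than are shown below. What is called first, only, known or untested is meant among the compounds shown, and "the series" means these compounds.

In an ADME assay on HepG2 cells (Homo sapiens) for cytotoxicity, read by luminescence, CellTiter-Glo and ATP content, with a stated time of 72 h (on this read-out lower numbers stand for an effect already at smaller amounts and higher numbers for an effect only at larger amounts of compound), compound 3 `COc1cccc(CNCCCNc2ccnc3cc(Cc4ccc(F)cc4Cl)ccc23)c1O` gives 2350 nM, the lowest of the three numbers in hand. Compound 1 `COc1ccc(Oc2ccc3c(NCCCNCc4cccc(OC)c4O)ccnc3c2)cc1` gives 5500 nM in this assay, and compound 2 `COc1ccc(-c2ccc3c(NCCCNCc4ccco4)ccnc3c2)cc1` gives 6000 nM; these two values lie within the scatter of each other. Among the compounds with values here, the one measured step that touches compound 3 is a 2.3-fold lower number from compound 1 to compound 3 (0.37 log units; beyond the scatter), a modest move.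

Compound 4 `COc1ccc(-c2ccc3c(NCCCNCc4cccc(OC)c4O)ccnc3c2)cc1` differs from compound 3 in a single place: 4-methoxyphenyl in place of 2-chloro-4-fluorobenzyl on an aromatic carbon. Within the data shown here, no measured pair shows exactly this exchange, but compound 2 already carries the 4-methoxyphenyl group and sits close to compound 1, and the step from compound 1 to compound 3 shows that removing the 2-chloro-4-fluorobenzyl group in favour of a methoxy-bearing aryl group is linked with a higher number.

Compound 4 is therefore expected to show a higher number than compound 3, with the step of a 2.3-fold higher number from compound 3 to compound 4 (0.37 log units; beyond the scatter) estimated to roughly undo the earlier one. The expected value for compound 4 in this assay is 5500 nM, within a range of 2500 nM to 12000 nM.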

Compound 4, half-maximal effective concentration in the HepG2 assay: 1600 nM
Estimate against measurement, compound 4: 3.4-fold (0.54 log units) above, and the stated range ends above it.
By their numbers in the HepG2 assay, from the lowest: compounds 4 and 3 (each within the scatter of the next); then compounds 1 and 2 (each within the scatter of the next).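

In the HepG2 assay, moving from the benzyl arm to the directly attached aryl ring on this aromatic carbon makes no clear difference: a 1.5-fold lower number from compound 3 to compound 4 (0.17 log units; within the scatter). Compound 4 does stand apart from the other two, with a 3.4-fold lower number from compound 1 to compound 4 (0.54 log units; beyond the scatter) for 4-methoxyphenyl in place of 4-methoxyphenoxy on the same carbon, and a 3.8-fold lower number from compound 2 to compound 4 (0.57 log units; beyond the scatter) for the change on the chain, 2-hydroxy-3-methoxyphenyl in place of furan-2-yl. The exchange at this position does separate compounds 3 and 4 in another measurement: in a physicochemical assay for solubility, with a stated time of 18 h, at pH 7.4 (on this read-out lower numbers stand for lower solubility and higher numbers for higher solubility), compound 3 gives 4200 nM and compound 4 gives 32000 nM, so the compound with the 4-methoxyphenyl group is the more soluble: the measured solubility of compound 3, 4200 nM, and of compound 4, 32000 nM, a 7.6-fold higher number (0.88 log units; beyond the scatter)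

The compounds shown do not tell whether the methoxy group or the aryl ring itself goes with this higher solubility. Going by these compounds, whether an amine or a carboxylic acid on the 4-methoxyphenyl ring would keep it also remains open.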